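Flavone series: aryl variation and cytotoxicity, working notes

This account rests on a few compounds, and the source may have more. Where it says the series, first, only, none or still open, it means among the compounds named here.

Measured compounds:
compound 1 `COc1ccc(-c2cc(=O)c3c(O)cc(OCCCCN4CCN(C)CC4)c(OC)c3o2)cc1`: 2320 nM
compound 2 `COc1c(OCCCCN2CCN(C)CC2)cc(O)c2c(=O)cc(-c3ccc(C(F)(F)F)cc3)oc12`: 2890 nM

In a functional assay on A549 cells (Homo sapiens) for cytotoxicity, read by MTT assay, with a stated time of 72 h (on this read-out lower numbers stand for stronger inhibition and higher numbers for weaker inhibition), compound 1 gives 2320 nM, and compound 2 gives 2890 nM. Within the data shown here, on the two numbers so far compound 2 carries the higher one, but the difference is only a 1.2-fold higher number from compound 1 to compound 2 (0.10 log units; within the scatter), so the two compounds cannot be told apart here.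

Compound 3 `COc1ccccc1-c1cc(=O)c2c(O)cc(OCCCCN3CCN(C)CC3)c(OC)c2o1` is not yet measured. It differs from compound 2 by 2-methoxyphenyl in place of 4-(trifluoromethyl)phenyl on an aromatic carbon. Among the measured compounds shown here, the single measured step, a 1.2-fold higher number from compound 1 to compound 2 (0.10 log units; within the scatter), also exchanged a group on that aryl ring and did not leave the scatter; no measured step addresses a 2-methoxyphenyl in this position. On that basis no step beyond the scatter is expected in this assay for compound 3. Compound 3 is expected to give about 2500 nM, between 1100 nM and 5800 nM. The expected step of a 1.2-fold lower number from compound 2 to compound 3 (0.06 log units; within the scatter) is thus small.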

Compound 3, half-maximal inhibitory concentration: 6790 nM
Beside the measured number, compound 3's estimate is 2.7-fold (0.43 log units) below it; the measured number lies above the stated range.
By their numbers in this assay, from the lowest: compounds 1 and 2 (each within the scatter of the next); then compound 3.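

In this assay, among these compounds, the aryl group at this position can shift the number: exchanging 4-(trifluoromethyl)phenyl for 2-methoxyphenyl gives a 2.3-fold higher number from compound 2 to compound 3 (0.37 log units; beyond the scatter) and is the first step to leave the scatter. Moving the methoxy group around the aryl ring gives a 2.9-fold higher number from compound 1 to compound 3 (0.47 log units; beyond the scatter) and also leaves the scatter, so between these two compounds the place of that group counts, whereas the exchange of methoxy for trifluoromethyl between compound 1 and compound 2 did not separate them. Nothing available here explains the higher number with 2-methoxyphenyl.

As far as these compounds go, it remains open whether an unsubstituted phenyl or a hydroxyl on that aryl ring would fall with compound 1 and compound 2 or with compound 3. Also open, from the compounds shown here alone, is whether the step holds with a morpholine in place of the methylpiperazine at the end of the chain.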